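From 3-fluorophenyl to 4-fluorophenyl on a carbonyl carbon

This account rests on a few compounds, and the source may have more. Where it says the series, first, only, none or still open, it means among the compounds named here.

- compound 1 `COc1cc2ncnc(Nc3ccc(NC(=O)c4ccccc4OC)cc3)c2cc1OC` gives > 100000 nM (a limit, not a number)
- compound 2 `CCc1ccc(C(=O)Nc2ccc(Nc3ncnc4cc(OC)c(OC)cc34)cc2)cc1` gives 65000 nM
- compound 3 `COc1cc2ncnc(Nc3ccc(NC(=O)c4cccc(F)c4)cc3)c2cc1OC` gives 13600 nM

All three compounds were read in a functional assay on MCF7 cells (Homo sapiens) for inhibition, read by MTT assay (on this read-out lower numbers stand for stronger inhibition and higher numbers for weaker inhibition), and share one core. Compound 3 holds the lowest of the numbers, and the measured steps set it apart from the other two. The gap to the nearest number is a 4.8-fold lower number from compound 2 to compound 3 (0.68 log units; beyond the scatter) and the comparison with the limit gives an at least 7.3-fold lower number from compound 1 to compound 3 (0.86 log units; beyond the scatter). The remaining pair shows an at least 1.5-fold lower number from compound 1 to compound 2 (0.18 log units; that floor lies within the scatter).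

Compound 4 `COc1cc2ncnc(Nc3ccc(NC(=O)c4ccc(F)cc4)cc3)c2cc1OC` differs from compound 3 in one place: 4-fluorophenyl in place of 3-fluorophenyl on a carbonyl carbon. The two have the same atoms, joined differently, with 4-fluorophenyl in place of 3-fluorophenyl on a carbonyl carbon.

The steps above all exchange the group on that carbonyl carbon, so they bear on this change, yet none of them moves the fluorine alone. Compound 3 sits at the low end of this small set, and the step from its nearest neighbour, a 4.8-fold lower number from compound 2 to compound 3 (0.68 log units; beyond the scatter), marks the largest size that seems reasonable here. A small rise in this assay is therefore expected, rather than a fall. The estimated step is a 1.4-fold higher number from compound 3 to compound 4 (0.15 log units; within the scatter) and it is expected to stay near the scatter. The expected value for compound 4 is 19000 nM (estimated range 7000 nM to 60000 nM).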

Compound 4, half-maximal inhibitory concentration: 27000 nM
For compound 4 the middle estimate is 1.4-fold (0.15 log units) below the measured one, and the stated range covers the measured number.
By their numbers in this assay, from the lowest: compounds 3 and 4 (each within the scatter of the next); then compound 2. At a limit, above all of these: compound 1.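

In this assay, within the data shown here, the earlier compounds never moved the fluorine alone, and this pair does: a 2.0-fold higher number from compound 3 to compound 4 (0.30 log units; within the scatter), so the 3-fluorophenyl and 4-fluorophenyl groups on a carbonyl carbon are not told apart on this read-out. Among these compounds, the new compound also gives the first single-place exchange on the aromatic ring itself, fluoro in place of ethyl on an aromatic carbon, with a 2.4-fold lower number from compound 2 to compound 4 (0.38 log units; beyond the scatter), a modest step beyond the scatter that rests on this one pair. Compound 1 stands at a limit, so an at least 3.7-fold lower number from compound 1 to compound 4 (0.56 log units; beyond the scatter) gives only a floor for that step and no true size: the limit of > 100000 nM in this assay, at which 1 of the 4 values shown sits.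

The compounds shown leave open whether a chlorine, a nitrile or an amine in place of the fluorine on that ring would read with compound 3 and compound 4 or nearer to compound 2. Also open, on these data alone, is whether a carboxylic acid or a chain longer than ethyl would be tolerated there, and whether the lack of a clear difference between the two fluorophenyl groups would hold on another core.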